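The compounds below may be only part of what the source reports. "The series", "measured", "known", "first", "only" and "open" are said of these compounds alone.

Of the compounds shown here, three sharing one core have been measured so far. Compound 1 `O=C(O)Cc1sc(C(c2ccccc2)c2ccccc2)nc1-c1ccccc1` gives 370 nM in an in vitro functional assay on HEK285-7 cells for antagonist activity at prostaglandin D2 receptor 2 (Homo sapiens), read by BRET and beta-arrestin recruitment; on this read-out higher numbers stand for weaker inhibition and lower numbers for stronger inhibition. Compound 2 `NS(=O)(=O)c1cccc(-c2nc(C(c3ccc(F)cc3)c3ccc(F)cc3)sc2CC(=O)O)c1` gives 710 nM in this assay, the highest of the three numbers, though its gap to compound 1 lies within the scatter. Compound 3 `O=C(O)Cc1sc(C(c2ccccc2)c2ccc(F)c(F)c2)nc1-c1ccc(F)cc1` gives 64 nM in this assay, a number lower than that of compound 2 by a margin beyond the scatter; compound 3, however, differs from compound 2 in more than one place, so no single change can be credited.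

Compound 4 `O=C(O)Cc1sc(C(c2ccc(F)cc2)c2ccc(F)cc2)nc1-c1ccnc(O)c1` has not yet been measured. It differs from compound 2 in a single place: 2-hydroxypyridin-4-yl in place of 3-sulfamoylphenyl on an aromatic carbon The rest of the molecule, including the bis(4-fluorophenyl)methyl group and the carboxymethyl group, is unchanged.

Going by the values given here, no measured pair isolates this change. Since compound 1 gives 370 nM with a plain phenyl at the same place while compound 2 gives 710 nM, the evidence suggests that the group at this position moves the number only modestly. Compound 4 is therefore expected to show a step of a 1.8-fold lower number from compound 2 to compound 4 (0.25 log units; within the scatter) in this assay, no further than the scatter. Compound 4 is estimated at 400 nM, with a likely range from 120 nM to 1400 nM.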

Compound 4, half-maximal inhibitory concentration: 890 nM
Estimate against measurement, compound 4: 2.2-fold (0.35 log units) below, within the range that was stated.
By their numbers in this assay, from the lowest: compound 3; then compounds 1, 2 and 4 (each within the scatter of the next, the first and the last beyond it).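

In this assay, going by these compounds alone, putting 2-hydroxypyridin-4-yl in place of 3-sulfamoylphenyl on the aromatic carbon next to the ring nitrogen gives a 1.3-fold higher number from compound 2 to compound 4 (0.10 log units; within the scatter), and this is the first pair among the compounds to isolate a single change at this position. Within the data shown here, the position therefore takes a six-membered aromatic ring with 1 hetero atom and 7 heavy atoms in place of a carbon-only ring group with 10 heavy atoms, at the same count of hydrogen-bond donors and acceptors, with no step that can be read beyond the scatter. No measurement at hand explains why the two groups cannot be told apart on this read-out.

What the compounds shown leave open is how a group such as an amine, a carboxylic acid or a 2-methoxypyridin-4-yl would behave at this position. As far as these compounds go, it is also open whether 2-hydroxypyridin-4-yl would behave the same way if the bis(4-fluorophenyl)methyl group were replaced by the unsubstituted diphenylmethyl group of compound 1, since this pair covers only one setting of the rest of the molecule.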